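Compound 3 to compound 4: adding piperidin-1-yl to the chain

The source may report more compounds than this note shows. Statements on the series, on what has been measured and on what is new or still open speak of the compounds shown alone.

In a functional assay on Raji cells (Homo sapiens) for antiproliferative activity, read by MTT assay, with a stated time of 48 h (a higher number here means a weaker inhibitor, a lower number a stronger inhibitor), compound 1 (`Cn1c(N)c(-c2nc3ccccc3[nH]2)c2nc(C#N)c(C#N)nc21`) gives > 50000 nM, a limit of the assay. Compound 2 (`N#Cc1nc2c(-c3nc4ccccc4[nH]3)c(N)n(CCN3CCCC3)c2nc1C#N`) gives > 50000 nM, also a limit. Compound 3 (`CCCn1c(N)c(-c2nc3ccccc3[nH]2)c2nc(C#N)c(C#N)nc21`) gives > 50000 nM, again a limit and not a number, so its position is shared with the other two: the limit of > 50000 nM in this assay, at which 3 of the 3 values shown sit.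

Compound 4 (`N#Cc1nc2c(-c3nc4ccccc4[nH]3)c(N)n(CCCN3CCCCC3)c2nc1C#N`) turns the propyl of compound 3 into 3-(piperidin-1-yl)propyl: piperidin-1-yl in place of hydrogen on a saturated chain carbon, three bonds along the chain from an aromatic nitrogen.

For the measured compounds named here, three measured steps bear on this change. The closest is a step that the two limits leave unreadable from compound 1 to compound 2, which also places a saturated ring on the chain. The other two are a step that the two limits leave unreadable from compound 1 to compound 3 and a step that the two limits leave unreadable from compound 2 to compound 3. None of the three has a readable size, so they set no size for the new step. Compound 4 is therefore expected to stay in the same region of this assay, most likely at the limit again. The estimated a number no higher from compound 3 to compound 4 (the limit leaves the size open) is small, and any measurable shift is expected toward a stronger inhibitor. For compound 4 the expected value is 50000 nM, with an estimated range of 15000 nM to 100000 nM.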

Compound 4, half-maximal inhibitory concentration: 3380 nM
Beside the measured number, compound 4's estimate is 15-fold (1.17 log units) above it, and the stated range ends above it.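

In this assay, the steps among compound 1, compound 2 and compound 3 cannot be read, and compound 4 alone gives a measured number: the limit of > 50000 nM in this assay, at which 3 of the 4 values shown sit.

The 3-(piperidin-1-yl)propyl chain gives an at least 14-fold lower number from compound 3 to compound 4 (1.17 log units; beyond the scatter), so this position can move the series off the limit, which the propyl chain alone does not do. The other two new steps are an at least 14-fold lower number from compound 2 to compound 4 (1.17 log units; beyond the scatter) and an at least 14-fold lower number from compound 1 to compound 4 (1.17 log units; beyond the scatter), and they show that a saturated ring on the chain is not enough in itself, since compound 2 carries pyrrolidin-1-yl and remains at a limit.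

Compound 2 and compound 4 differ in both ring and chain length, so the two contributions stay unseparated. On these data alone, how a 2-(piperidin-1-yl)ethyl chain, a 3-(pyrrolidin-1-yl)propyl chain or a longer chain ending in piperidin-1-yl would read remains open.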